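Oral exposure in cynomolgus monkey: compound 2 to compound 3

This account rests on a few compounds, and the source may have more. Where it says the series, first, only, none or still open, it means among the compounds named here.

Measured compounds:
compound 1 `CCS(=O)(=O)NC(=O)c1nc(N(CC2CC2)[C@H](C)c2ccc(-c3cc(Cl)ccc3-c3nc(=O)o[nH]3)cc2)sc1C`: 2170 ng.h/mL
compound 2 `Cc1ccc(-c2nc(=O)s[nH]2)c(-c2ccc([C@@H](C)N(CC3CC3)c3nc(C(=O)NS(=O)(=O)C4CC4)c(C4CC4)s3)cc2)c1`: 39800 ng.h/mL

In an ADME assay on the whole organism (Macaca fascicularis) for pharmacokinetics, at a dose of 1 mg/kg by the oral route (on this read-out lower numbers stand for lower exposure and higher numbers for higher exposure at the dose given), compound 2 gives the highest of the two numbers; the nearest, compound 1, sits at a lower number, beyond the scatter. Compound 3 `CNC(=O)c1ccc(C)cc1-c1ccc([C@@H](C)N(CC2CC2)c2nc(C(=O)NS(=O)(=O)C3CC3)c(C3CC3)s2)cc1` differs from compound 2 by a group of 4 heavy atoms (2 carbon, 1 nitrogen, 1 oxygen; no ring) in place of a group of 6 heavy atoms (2 carbon, 2 nitrogen, 1 oxygen, 1 sulfur; one five-membered aromatic ring with 3 hetero atoms), on an aromatic carbon. Among the compounds with values here, no measured pair shows this exchange, so its size cannot be read from the numbers. A moderate fall is expected, as a 3.3-fold lower number from compound 2 to compound 3 (0.52 log units; beyond the scatter). Compound 3 is estimated at 12000 ng.h/mL, with a wide range from 2000 ng.h/mL to 60000 ng.h/mL.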

Compound 3, area under the concentration-time curve: 21400 ng.h/mL
Beside the measured number, compound 3's estimate is 1.8-fold (0.25 log units) below it; low and high end bracket the measured number.
By their numbers in this assay, from the lowest: compound 1; then compounds 3 and 2 (each within the scatter of the next).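

In this assay, methylcarbamoyl replaces the five-membered aromatic ring with 3 hetero atoms on the aromatic carbon ortho to a large group and para to a methyl group, giving a 1.9-fold lower number from compound 2 to compound 3 (0.27 log units; within the scatter). At this position, exposure in this range therefore does not depend on that ring, and a group with no ring serves as well within the scatter. Nothing at hand explains why the two groups read alike. From the compounds shown here alone, whether a carboxylic acid or a primary amide at this position would also read alike remains open. So does the effect of a longer chain on the amide nitrogen.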